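A few compounds are considered here, and "the series" means these few. Any claim that something is new, unique, unknown or untested is made for them only; others in the source may bear on it.

In a functional assay on MDA-MB-231 cells (Homo sapiens) for inhibition, read by MTT assay, with a stated time of 48 h (a higher number here means a weaker inhibitor, a lower number a stronger inhibitor), compound 1 `O=C(NC1CC1)c1[nH]cnc1-c1nc2ccccc2[nH]1` gives 35200 nM and compound 2 `O=C(NC1CCC1)c1[nH]cnc1-c1nc2ccccc2[nH]1` gives 33800 nM. Compound 3 `O=C(NC1CCCCCC1)c1[nH]cnc1-c1nc2ccccc2[nH]1` has no exact number, only an assay limit: > 40000 nM. Compound 4 `O=C(NCc1cccs1)c1[nH]cnc1-c1nc2ccccc2[nH]1` carries (thiophen-2-yl)methyl in place of cycloheptyl on an amide-type nitrogen. The measured steps that bear on this change all alter the group on that same nitrogen: a 1.0-fold lower number from compound 1 to compound 2 (0.02 log units; within the scatter), an at least 1.1-fold higher number from compound 1 to compound 3 (0.05 log units; that floor lies within the scatter) and an at least 1.1-fold higher number from compound 2 to compound 3 (0.07 log units; that floor lies within the scatter). The last two are only floors, and none goes beyond the scatter. None of these compounds has an aromatic ring there, so the guide is loose. The expected step stays within the scatter: an at least 1.3-fold lower number from compound 3 to compound 4 (0.12 log units; that floor lies within the scatter). Compound 4 is estimated at 30000 nM, with an expected range from 14000 nM to 50000 nM.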

Compound 4, half-maximal inhibitory concentration: 35100 nM
The estimate for compound 4 lay 1.2-fold (0.07 log units) below the measured number; measured number inside the range.
By their numbers in this assay, from the lowest: compounds 2, 4 and 1 (each within the scatter of the next). At a limit, above all of these: compound 3.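

In this assay, an aromatic ring on the amide-type nitrogen, (thiophen-2-yl)methyl, reads no differently from the small cycloalkyl rings: a 1.0-fold higher number from compound 2 to compound 4 (0.02 log units; within the scatter) and a 1.0-fold lower number from compound 1 to compound 4 (0.00 log units; within the scatter). Replacing cycloheptyl gives an at least 1.1-fold lower number from compound 3 to compound 4 (0.05 log units; that floor lies within the scatter), which is only a floor. Compound 3 holds a limit, not a number: the limit of > 40000 nM in this assay, at which 1 of the 4 values shown sits.

As far as these compounds go, whether any group on this nitrogen can move the number beyond the scatter stays open, for example a chain ending in an amine or a carboxylic acid. So does whether a benzyl group would read like (thiophen-2-yl)methyl.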